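Removing the Chloro Group from Compound 2

The source may report more compounds than this note shows. Statements on the series, on what has been measured and on what is new or still open speak of the compounds shown alone.

Compound 1 `O=C(Nc1ccc(Oc2ccnc3[nH]ccc23)cc1)c1nn(-c2ccc(Cl)cc2)ccc1=O` gives 25100 nM in a functional assay on A549 cells (Homo sapiens) for cytotoxicity, read by MTT assay, with a stated time of 72 h; a lower number here means a stronger inhibitor, a higher number a weaker inhibitor.
Compound 2 `Cn1ccc2c(Oc3ccc(NC(=O)c4nn(-c5ccc(Cl)cc5)ccc4=O)cc3)ccnc21` gives > 60000 nM in this assay, which is a limit of the assay and not a number.

Going by these compounds, compound 2 thus stands at the limit (the limit of > 60000 nM in this assay, at which 1 of the 2 values shown sits), so its true value is unknown. Compound 3 `Cn1ccc2c(Oc3ccc(NC(=O)c4nn(-c5ccccc5)ccc4=O)cc3)ccnc21` differs from compound 2 by hydrogen in place of chloro on an aromatic carbon. Among the measured compounds shown here, the only measured step, an at least 2.3-fold higher number from compound 1 to compound 2 (0.37 log units; beyond the scatter), concerns a different change and does not bear on this one. With nothing to guide the direction, no step beyond the scatter is expected, a step that the limit leaves unreadable from compound 2 to compound 3. Compound 3 is therefore expected at 70000 nM, within a range from 30000 nM to 200000 nM, and will likely again return only a limit.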

Compound 3, half-maximal inhibitory concentration: 51700 nM
Compound 3: the middle estimate sits 1.4-fold (0.13 log units) above what was measured; the measured number falls inside the stated range.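

Going from 4-chlorophenyl to phenyl gives an at least 1.1-fold lower number from compound 2 to compound 3 (0.06 log units; that floor lies within the scatter) in this assay, so this is the first reading at this position, and it shows only a floor for the change. Compound 2 holds only a limit of the assay: the limit of > 60000 nM in this assay, at which 1 of the 3 values shown sits. Going by these compounds, the true size of the step therefore stays unknown, and it may be small or large.

Open, on these data alone, is whether an amine or a methoxy group in place of the hydrogen on this phenyl ring would shift the number. Also open, as far as these compounds go, is whether losing the chloro would act the same way with hydrogen on the aromatic nitrogen, as in compound 1.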